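Sulfamoyl for Chloro, Repeated on a Second Core

This account rests on a few compounds, and the source may have more. Where it says the series, first, only, none or still open, it means among the compounds named here.

Compound 1, `Cc1ccc(-c2nn(-c3ccc(Cl)cc3)cc2/C=C\C(=O)c2ccc(Cl)cc2)cc1`: 49.2%
Compound 2, `Cc1ccc(-c2nn(-c3ccc(S(N)(=O)=O)cc3)cc2/C=C\C(=O)c2ccc(Cl)cc2)cc1`: 53.3%
Compound 3, `Cc1ccc(-c2nn(-c3ccc(Cl)cc3)cc2C(CC(=O)c2ccc(Cl)cc2)C(=O)c2ccc(F)cc2)cc1`: 25.9%

Of the compounds shown here, three have been measured in a functional assay on the whole organism (strain Wistar albino) for inhibition, with Rattus norvegicus as the target, read by paw edema, with stated times of 1 h and 2 h, at a dose of 0.32 mmol/kg by the intraperitoneal route; a higher number here means more inhibition at the dose given (going by the name of the read-out), a lower number less inhibition. Compound 1, `Cc1ccc(-c2nn(-c3ccc(Cl)cc3)cc2/C=C\C(=O)c2ccc(Cl)cc2)cc1`, gives 49.2%, and compound 2, `Cc1ccc(-c2nn(-c3ccc(S(N)(=O)=O)cc3)cc2/C=C\C(=O)c2ccc(Cl)cc2)cc1`, gives 53.3%. The two differ by sulfamoyl in place of chloro on an aromatic carbon, and the step is a number 4.1 percentage points higher from compound 1 to compound 2 (within the scatter). Compound 3, `Cc1ccc(-c2nn(-c3ccc(Cl)cc3)cc2C(CC(=O)c2ccc(Cl)cc2)C(=O)c2ccc(F)cc2)cc1`, gives 25.9%, the lowest of the three numbers, beyond the scatter from both compound 1 and compound 2. How the core of compound 3 differs from the core of compound 1 is not broken down here.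

Compound 4, `Cc1ccc(-c2nn(-c3ccc(S(N)(=O)=O)cc3)cc2C(CC(=O)c2ccc(Cl)cc2)C(=O)c2ccc(F)cc2)cc1`, has not yet been measured in this assay. It differs from compound 3 by sulfamoyl in place of chloro on an aromatic carbon, the same change that separates compound 1 from compound 2, at a place described in the same words. That change occurs twice among these four compounds, and its one measured instance lies within the scatter. Compound 4 is therefore expected to sit close to compound 3, because the same change gave a number 4.1 percentage points higher from compound 1 to compound 2 (within the scatter) when it was made once before. The expected step is a number 4.1 percentage points higher from compound 3 to compound 4 (within the scatter), set beside that earlier one. Compound 4 is estimated to give 30% in this assay, with a range from 18% to 42%.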

Compound 4, a percentage reported as inhibition, in the whole organism at one dose (the size of the read-out at that dose, not a potency): 53.5%
Beside the measured number, compound 4's estimate is 23.5 percentage points below it; measured number outside the range, above it.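

On the core of compound 3, replacing 4-chlorophenyl with 4-sulfamoylphenyl gives, in this assay, a number 27.6 percentage points higher from compound 3 to compound 4 (beyond the scatter), a step well clear of the usual scatter. The change therefore did not carry over from one core to the other with the same size, and a step measured on one core would have been a poor guide to the step on the other: the same change on two cores in this assay, a number 4.1 percentage points higher (within the scatter) from compound 1 to compound 2 and a number 27.6 percentage points higher (beyond the scatter) from compound 3 to compound 4, 23.5 percentage points apart, beyond the scatter of two such steps. This shows that the size of the step depended on the core in these two pairs, but it rests on one pair per core at a single dose and does not show why the two steps differ or establish a rule for any further core.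

The compounds shown leave open whether the large step on the core of compound 3 belongs to sulfamoyl itself or would also appear with another group in place of chloro, such as a carboxylic acid or an amine. They also leave open which feature of the core of compound 3, as distinct from the core of compound 1, goes with the larger step, and whether a third core would follow either pair.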